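This account rests on a few compounds, and the source may have more. Where it says the series, first, only, none or still open, it means among the compounds named here.

Going by the values given here, in a functional assay on MDA-MB-231 cells (Homo sapiens) for antiproliferative activity, read by MTT assay, with a stated time of 24 h (a higher number here means a weaker inhibitor, a lower number a stronger inhibitor), compound 2 (`COc1ccc(-c2noc(C3CCCN3)n2)cc1OC1CCCC1`) gives 212000 nM, the only actual number so far. Compound 1 (`c1ccc(-c2noc(-c3ccncc3)n2)cc1`) reports > 1000000 nM, which is a limit of the assay. Compound 3 (`COc1cc(-c2noc(-c3ccncc3)n2)ccc1OCc1ccccc1`) reports > 1000000 nM, also a limit. Among the compounds with values here, both carry a six-membered aromatic ring with 1 hetero atom on the shared core, but they differ from compound 2 elsewhere too, so no measured step isolates the change. Compound 4 (`COc1ccc(-c2noc(-c3cccnc3)n2)cc1OC1CCCC1`) has pyridin-3-yl in place of pyrrolidin-2-yl on an aromatic carbon. In this assay a weakening is expected, resting on compound 1, compound 3 and (the limit of > 1000000 nM in this assay, at which 2 of the 3 values shown sit). The estimated change is a 1.9-fold higher number from compound 2 to compound 4 (0.28 log units; within the scatter). Compound 4 is estimated at 400000 nM, with an expected range of 100000 nM to 1000000 nM.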

Compound 4, half-maximal inhibitory concentration: > 1000000 nM
Compound 4: only a limit was reported (the forecaster's own chance of this, stated with the estimate: 35%); middle value at least 2.5-fold (0.39 log units) away from the limit.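

In this assay compound 4 gives > 1000000 nM, which is a limit of the assay. Pyridin-3-yl in place of pyrrolidin-2-yl gives an at least 4.7-fold higher number from compound 2 to compound 4 (0.67 log units; beyond the scatter), the first measured step in the series, so activity at this position depends on the group carried there. The step is a lower bound only, and compound 2 remains the sole compound with an actual number: the limit of > 1000000 nM in this assay, at which 3 of the 4 values shown sit.

Whether the ring's aromatic character, its size or the hydrogen-bond donor accounts for the step stays open. A piperidine ring or an open-chain amine at this position would help separate these.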